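The source may report more compounds than this note shows. Statements on the series, on what has been measured and on what is new or still open speak of the compounds shown alone.

Working notes on the series. In an ADME assay on microsomes from liver (Mus musculus) for metabolic stability, read by LC-MS, with a stated time of 30 min, tested at 0.1 uM (on this read-out lower numbers stand for a less stable compound and higher numbers for a more stable compound), compound 1 `COc1cccc(Nc2cc3[nH]c(-c4cccc(C(F)(F)F)c4)nc3cn2)n1` gives 60%. Compound 2 `COc1ccnc(Nc2cc3[nH]c(-c4cccc(C(F)(F)F)c4)nc3cn2)c1` gives 62% in this assay. Compound 3 `COc1ccc(Nc2cc3[nH]c(-c4cccc(C(F)(F)F)c4)nc3cn2)nc1` gives 33% in this assay, the lowest of the three numbers shown; its nearest neighbour is compound 1 and its furthest compound 2, both gaps beyond the scatter. The measured steps are a number 2 percentage points higher from compound 1 to compound 2 (within the scatter), a number 27 percentage points lower from compound 1 to compound 3 (beyond the scatter) and a number 29 percentage points lower from compound 2 to compound 3 (beyond the scatter); each moves a methoxy on the same ring, none removes it or exchanges the ring. Compound 4 `FC(F)(F)c1cccc(-c2nc3cnc(Nc4cccnn4)cc3[nH]2)c1` differs from compound 3 by pyridazin-3-yl in place of 5-methoxypyridin-2-yl on a nitrogen on an aromatic ring. Among the measured compounds shown here, no measured step covers this change directly; the steps into compound 3 only show that its methoxy position sits with the lowest number. For compound 4 a modest rise in this assay is expected, a number 17 percentage points higher from compound 3 to compound 4 (beyond the scatter), with wide uncertainty. The estimate for compound 4 is 50%, within 25% to 75%.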

Compound 4, percent of the compound remaining: 51%
Compound 4: middle estimate off by 1 percentage points, on the low side; the range from low to high includes it.
By their numbers in this assay, from the lowest: compound 3; then compounds 4, 1 and 2 (each within the scatter of the next, the first and the last beyond it).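

Exchanging the ring on the nitrogen, rather than moving its methoxy, gives a number 18 percentage points higher from compound 3 to compound 4 (beyond the scatter) in this assay. The same exchange gives a number 9 percentage points lower from compound 1 to compound 4 (within the scatter) and a number 11 percentage points lower from compound 2 to compound 4 (beyond the scatter), so a ring without methoxy stays separated from 4-methoxypyridin-2-yl but not from 6-methoxypyridin-2-yl. Nothing available explains these steps.

The compounds shown do not separate the loss of the methoxy from the entry of the second ring nitrogen. As far as these compounds go, how an unsubstituted pyridin-2-yl, or a pyridazin-3-yl carrying a methoxy or a morpholine, would read at this position stays open.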